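Ethoxycarbonyl in place of fluoro: expected cytotoxicity of compound 3

The compounds below may be only part of what the source reports. "The series", "measured", "known", "first", "only" and "open" are said of these compounds alone.

Compound 1 `O=C(/C=C/c1ccc2c(c1)B(O)OC2)c1ccc(F)cc1` gives 11800 nM in a toxicity assay on MCF-10A cells (Homo sapiens) for cytotoxicity, read by MTT assay, with a stated time of 48 h (on this read-out higher numbers stand for weaker inhibition and lower numbers for stronger inhibition), the lowest of the two numbers in hand; compound 2 `O=C(/C=C/c1ccc2c(c1)B(O)OC2)c1ccc(Br)cc1` gives 27800 nM. Among the measured compounds shown here, the one measured step, a 2.4-fold higher number from compound 1 to compound 2 (0.37 log units; beyond the scatter), is the only exchange made on that aromatic carbon. Compound 3 `CCOC(=O)c1ccc(C(=O)/C=C/c2ccc3c(c2)B(O)OC3)cc1` differs from compound 1 by ethoxycarbonyl in place of fluoro on an aromatic carbon. For the measured compounds named here, no step involving this group has been measured, so the halogen exchange is the sole guide, and it pointed to a higher number when the substituent was changed. A modest rise is therefore expected, a 1.7-fold higher number from compound 1 to compound 3 (0.23 log units; within the scatter). Compound 3 is estimated at 20000 nM, within 8000 nM to 50000 nM.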

Compound 3, half-maximal inhibitory concentration: 12900 nM
Compound 3: middle estimate off by 1.6-fold (0.19 log units), on the high side, and the stated range covers the measured number.
By their numbers in this assay, from the lowest: compounds 1 and 3 (each within the scatter of the next); then compound 2.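

With a 1.1-fold higher number from compound 1 to compound 3 (0.04 log units; within the scatter) in this assay, the aromatic carbon para to a large group takes ethoxycarbonyl, with 5 heavy atoms and 2 hydrogen-bond acceptors, in place of fluoro without a step beyond the scatter. Against bromo the same group gives a 2.2-fold lower number from compound 2 to compound 3 (0.33 log units; beyond the scatter), so among these three compounds the heavy-atom count of the substituent does not set the order, and compound 2 alone stands apart. No measured evidence bears on the reason for this. Open, going by these compounds, is how a carboxylic acid, an amine or a longer ester chain on this carbon would read out.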